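Swapping Chloro for Ethyl in Compound 1

The source may hold more compounds than are shown below. What is called first, only, known or untested is meant among the compounds shown, and "the series" means these compounds.

Within the data shown here, in a functional assay on BXPC-3 cells (Homo sapiens) for cytotoxicity, read by MTT assay, with a stated time of 72 h (on this read-out higher numbers stand for weaker inhibition and lower numbers for stronger inhibition), compound 1 `O=C1C(Nc2ccc(-c3ccc(Cl)cc3)cc2)=CC(=O)c2ncncc21` gives 10100 nM, the higher and therefore weaker of the two numbers measured so far. In this assay, compound 2 `CN1CCN(c2ccc(NC3=CC(=O)c4ncncc4C3=O)cc2)CC1` gives 900 nM. Among the measured compounds shown here, the only measured step is an 11-fold lower number from compound 1 to compound 2 (1.05 log units; beyond the scatter). This large step, beyond the usual scatter, comes with 4-methylpiperazin-1-yl in place of 4-chlorophenyl on an aromatic carbon.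

Compound 3 `CCc1ccc(-c2ccc(NC3=CC(=O)c4ncncc4C3=O)cc2)cc1` makes a smaller edit: ethyl in place of chloro on an aromatic carbon. Seen one bond further out, 4-chlorophenyl becomes 4-ethylphenyl. For the measured compounds named here, no measured pair makes this swap, and the data give no direction for it. The measured step of an 11-fold lower number from compound 1 to compound 2 (1.05 log units; beyond the scatter) replaces the whole 4-chlorophenyl group, so it says little about changing only the chloro. No step beyond the scatter is therefore expected in this assay. The expected change is small, an estimated 1.1-fold lower number from compound 1 to compound 3 (0.05 log units; within the scatter). Compound 3 is expected to give about 9000 nM, with an estimated range from 4000 nM to 20000 nM.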

Compound 3, half-maximal inhibitory concentration: 1600 nM
Compound 3: the middle estimate sits 5.6-fold (0.75 log units) above what was measured, outside the stated range (below it).
By their numbers in this assay, from the lowest: compounds 2 and 3 (each within the scatter of the next); then compound 1.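

The swap of chloro for ethyl is a small edit on an aromatic carbon para to a large group, with no ring, hydrogen-bond donor or hydrogen-bond acceptor on either side of the change, yet in this assay it gives a 6.3-fold lower number from compound 1 to compound 3 (0.80 log units; beyond the scatter) and so shows that this single position is far from indifferent. Among these compounds, it also changes how the earlier step of an 11-fold lower number from compound 1 to compound 2 (1.05 log units; beyond the scatter) reads, since replacing the whole 4-chlorophenyl group is not the only route to a number of that order: a 1.8-fold higher number from compound 2 to compound 3 (0.25 log units; within the scatter) leaves the 4-ethylphenyl and 4-methylpiperazin-1-yl compounds within the scatter of each other. Nothing at hand explains why this swap has the size it does.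

Going by these compounds, whether the step comes from losing the chloro or from gaining the ethyl stays open, as does how a methyl group, a longer propyl chain or an amine on this same aromatic carbon would read in this assay and where each would fall relative to compound 3. On these data alone, it is also open whether the same swap would carry a step of similar size in other cell lines.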